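This account rests on a few compounds, and the source may have more. Where it says the series, first, only, none or still open, it means among the compounds named here.

Of the compounds shown here, three that share one core have been tested in a toxicity assay on cells (Macrophage, Homo sapiens) for inhibition, read by MTT assay; a higher number here means a weaker inhibitor, a lower number a stronger inhibitor. Compound 1 `NCCCCNc1nc(-c2ccc(Cl)cc2)nc2ccccc12` gives 13000 nM there. Compound 2 `NCCNc1nc(-c2ccc(Cl)cc2)nc2ccccc12` gives 15000 nM in this assay. Compound 3 `NCCNc1nc(-c2ccc(F)cc2)nc2ccccc12` gives 64000 nM in this assay, the highest number of the three. Compound 2 and compound 1 differ by 2-aminoethyl in place of amino on a saturated chain carbon, two bonds along the chain from a nitrogen on an aromatic ring, which made a 1.2-fold lower number from compound 2 to compound 1 (0.06 log units; within the scatter). The cores of compound 2 and compound 3 differ by fluoro in place of chloro on an aromatic carbon, which made a 4.3-fold higher number from compound 2 to compound 3 (0.63 log units; beyond the scatter). Compound 4 `NCCCCNc1nc(-c2ccc(F)cc2)nc2ccccc12` has not yet been tested. It differs from compound 3 by 2-aminoethyl in place of amino on a saturated chain carbon, two bonds along the chain from a nitrogen on an aromatic ring, the same change at the same place that turns compound 2 into compound 1. Because a 1.2-fold lower number from compound 2 to compound 1 (0.06 log units; within the scatter) stayed within the scatter, the expected step is a 1.2-fold lower number from compound 3 to compound 4 (0.08 log units; within the scatter), small as well. Compound 4 is therefore expected to give about 53000 nM in this assay, most likely between 20000 nM and 140000 nM.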

Compound 4, half-maximal inhibitory concentration: 64000 nM
Estimate against measurement, compound 4: 1.2-fold (0.08 log units) below; the range from low to high includes it.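

Putting 2-aminoethyl in place of amino on the compounds carrying fluoro gives no change at the digits printed from compound 3 to compound 4 (within the scatter) in this assay, and this matches the step seen with chloro: the same change on two cores in this assay, a 1.2-fold lower number (0.06 log units; within the scatter) from compound 2 to compound 1 and no change at the digits printed (within the scatter) from compound 3 to compound 4, 1.2-fold (0.06 log units) apart, within the scatter of two such steps

Fluoro in place of chloro, now on the compounds with the longer chain, gives a 4.9-fold higher number from compound 1 to compound 4 (0.69 log units; beyond the scatter), which agrees with the earlier step: the same change on two cores in this assay, a 4.3-fold higher number (0.63 log units; beyond the scatter) from compound 2 to compound 3 and a 4.9-fold higher number (0.69 log units; beyond the scatter) from compound 1 to compound 4, 1.2-fold (0.06 log units) apart, within the scatter of two such steps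

So within these four compounds, each change kept about the same size when carried to the other core, but this rests on only two steps per change and shows nothing about other cores or other assays.

On these data alone, it remains open whether bromo or methoxy in place of chloro or fluoro would fit the same picture. As far as these compounds go, it is also open whether a chain longer than 4-aminobutyl would leave the number unchanged.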